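Shifting one fluorine in compound 3

The source may hold more compounds than are shown below. What is called first, only, known or untested is meant among the compounds shown, and "the series" means these compounds.

- Compound 1 `O=C1/C(=C/c2ccccc2F)CN(Cc2cn(Cc3ccccc3F)nn2)C/C1=C\c1ccccc1F` gives 6500 nM
- Compound 2 `Cc1ccc(/C=C2\CN(C(=S)SCc3cn(Cc4ccccc4F)nn3)C/C(=C\c3ccc(C)cc3)C2=O)cc1` gives 28400 nM
- Compound 3 `COc1ccc(/C=C2\CN(Cc3cn(Cc4ccc(F)cc4)nn3)C/C(=C\c3ccc(OC)cc3)C2=O)cc1` gives 49300 nM

All three numbers come from a functional assay on 4T1 cells (Mus musculus) for cytotoxicity, read by MTT assay, with a stated time of 24 h (on this read-out lower numbers stand for stronger inhibition and higher numbers for weaker inhibition), and no two of these compounds differ in just one place. Compound 3 cannot be told apart from compound 2 within the usual scatter, while compound 1 has a clearly lower number and so stronger inhibition. Compound 4 `COc1ccc(/C=C2\CN(Cc3cn(Cc4ccccc4F)nn3)C/C(=C\c3ccc(OC)cc3)C2=O)cc1` carries 2-fluorophenyl in place of 4-fluorophenyl on a saturated chain carbon bound to an aromatic nitrogen. Compound 1 at 6500 nM and compound 2 at 28400 nM also carry 2-fluorobenzyl but differ elsewhere too, so they offer only a weak hint. In this assay the expected change is a 1.5-fold lower number from compound 3 to compound 4 (0.19 log units; within the scatter) and no step beyond the scatter is expected. For compound 4 the estimate is 32000 nM with an expected range of 11000 nM to 70000 nM around it.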

Compound 4, half-maximal inhibitory concentration: 39400 nM
The estimate for compound 4 lay 1.2-fold (0.09 log units) below the measured number; the measured number falls inside the stated range.
By their numbers in this assay, from the lowest: compound 1; then compounds 2, 4 and 3 (each within the scatter of the next).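

In this assay, moving the fluorine gives a 1.3-fold lower number from compound 3 to compound 4 (0.10 log units; within the scatter), which lies within the usual scatter. Going by these compounds alone, this is the first comparison here that changes only one place, and it shows that 2-fluorobenzyl and 4-fluorobenzyl cannot be told apart on the core of compound 3. No measurement shown explains this result. Still open, going by these compounds, is whether a plain benzyl, or a benzyl carrying an amine or a carboxylic acid instead of fluorine, would shift the number beyond the scatter. On these data alone, whether this fluorine move behaves the same way on other cores also remains open.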